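A few compounds are considered here, and "the series" means these few. Any claim that something is new, unique, unknown or untested is made for them only; others in the source may bear on it.

Measured in an ADME assay (liver) for metabolic stability, with Liver microsome (Homo sapiens) as the target, read by LC-MS, using microsomes and NADPH, tested at 1 uM; a higher number here means that the compound lasts longer, a lower number that the compound disappears faster:
Compound 1 `CC(C)(C)c1cc(NC(=O)[C@@H]2CCCCN2CC2CCOCC2)no1`: 0.183 h
Compound 2 `CC(C)(C)c1cc(NC(=O)[C@@H]2CCCCN2C(=O)c2ccccc2)no1`: 0.683 h
Compound 3 `CC(C)(C)c1cc(NC(=O)[C@@H]2CCCCN2C(=O)N2CCOCC2)no1`: > 2 h, which is a limit of the assay, not a number.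

Compound 1 gives the lowest of the two numbers in this assay; the nearest is compound 2, a 3.7-fold higher number from compound 1 to compound 2 (0.57 log units; beyond the scatter). Compound 4 `CC(C)(C)c1cc(NC(=O)[C@@H]2CCCCN2C(=O)N2CCSCC2)no1` differs from compound 1 in one place: (thiomorpholin-4-yl)carbonyl in place of (oxan-4-yl)methyl on an amine nitrogen in a ring. The step of an at least 10-fold higher number from compound 1 to compound 3 (1.03 log units; beyond the scatter) is the closest comparison, with a carbonyl-linked six-membered ring with two hetero atoms entering in both cases; an at least 2.9-fold higher number from compound 2 to compound 3 (0.46 log units; beyond the scatter) points the same way, and the limit of > 2 h in this assay, at which 1 of the 3 values shown sits, caps what compound 3 can show. A large upward step is therefore expected, a 6.6-fold higher number from compound 1 to compound 4 (0.82 log units; beyond the scatter). Compound 4 is estimated at 1.2 h in this assay, within 0.5 h to 2.5 h, with a real chance that only a limit is reported.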

Compound 4, half-life: < 0.0834 h
Compound 4 gave a limit, no number; the forecaster's own chance of this, stated with the estimate: 30%; at least 14-fold (1.15 log units) between middle value and limit.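

Replacing morpholin-4-yl with thiomorpholin-4-yl on the carbonyl carbon gives an at least 23-fold lower number from compound 3 to compound 4 (1.37 log units; beyond the scatter) in this assay, so the carbonyl link alone does not secure a long half-life. Thiomorpholin-4-yl also falls short of phenyl on that carbon, with an at least 8.1-fold lower number from compound 2 to compound 4 (0.91 log units; beyond the scatter), and of (oxan-4-yl)methyl, which has no carbonyl, with an at least 2.1-fold lower number from compound 1 to compound 4 (0.34 log units; beyond the scatter). Compound 4 gives a limit, not a number, so these steps are minimum sizes: the limit of < 0.0834 h in this assay, at which 1 of the 4 values shown sits.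

The compounds shown do not tell whether the sulfur atom accounts for the drop. Going by these compounds, how piperazin-1-yl or the sulfone of thiomorpholin-4-yl would fare on that carbonyl carbon stays open.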